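The source may report more compounds than this note shows. Statements on the series, on what has been measured and on what is new or still open speak of the compounds shown alone.

Compound 2, with the structure `CN1CC[C@@H]2CC[C@H](O)C[C@@H]21`, is a small bicyclic amino alcohol whose ring nitrogen carries a methyl group. In an assay on HEK293 cells for displacement of a labelled ligand from Neuronal acetylcholine receptor; alpha4/beta4 (Rattus norvegicus), with a stated time of 4 h (a lower number here means a stronger inhibitor, a higher number a weaker inhibitor), compound 2 gives > 300000 nM, which is a limit of the assay rather than a measured number. Compound 1, with the structure `COCCO[C@H]1CC[C@H]2CCN(C)[C@H]2C1`, carries a 2-methoxyethyl group on the oxygen where compound 2 has a hydrogen. In this assay compound 1 gives > 300000 nM, again a limit of the assay. Within the data shown here, the step that the two limits leave unreadable from compound 1 to compound 2 is therefore of unreadable size, and the only evidence from the measured pair is the limit of > 300000 nM in this assay, at which 2 of the 2 values shown sit. So compound 2 stands on a limit, and the single other value shown is a limit as well.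

Compound 3, with the structure `O[C@H]1CC[C@H]2CCN[C@H]2C1`, differs from compound 2 by hydrogen in place of methyl on an amine nitrogen in a ring. Among the measured compounds shown here, no measured step touches this nitrogen, so the expectation can rest only on the fact that both measured compounds sit at the limit. Compound 3 is expected to remain near that limit, with an estimated value of 400000 nM and a range from 100000 nM to 2000000 nM. The step that the limit leaves unreadable from compound 2 to compound 3 is accordingly expected to stay within the scatter.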

Compound 3, inhibition constant: > 300000 nM
Compound 3: only a limit was reported; the forecaster's own chance of this, stated with the estimate: 80%; the middle value does not contradict the limit.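

In this assay compound 3 gives > 300000 nM, which is a limit of the assay and not a measured number. Among these compounds, compound 2 also stands at a limit, so no step between compound 2 and compound 3 can be read. The compounds shown leave open whether compound 1, compound 2 and compound 3 differ at all in this binding, and whether any change to the shared core would give a readable value.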